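Swapping the Ester for a Pyridylmethyl Amide

The source may hold more compounds than are shown below. What is called first, only, known or untested is meant among the compounds shown, and "the series" means these compounds.

In a functional assay on A549 cells (Homo sapiens) for antiproliferative activity, read by sulforhodamine B assay, with a stated time of 72 h (on this read-out lower numbers stand for stronger inhibition and higher numbers for weaker inhibition), compound 1 `CCOC(=O)c1cnc2ccc(-c3cnc(OC)c(NS(=O)(=O)c4ccc(F)cc4F)c3)cn12` gives 300 nM, the second highest of the three numbers measured. Compound 2 `CCOC(=O)c1cnc2ccc(-c3cnc(OC)c(NS(C)(=O)=O)c3)cn12` gives 230 nM, and compound 3 `CCCCS(=O)(=O)Nc1cc(-c2ccc3ncc(C(=O)OCC)n3c2)cnc1OC` gives 3560 nM. The steps of a 1.3-fold lower number from compound 1 to compound 2 (0.12 log units; within the scatter) and a 12-fold higher number from compound 1 to compound 3 (1.07 log units; beyond the scatter) both alter the group on the sulfonyl sulfur, which compound 4 leaves unchanged. Compound 4 `COc1ncc(-c2ccc3ncc(C(=O)NCc4ccncc4)n3c2)cc1NS(=O)(=O)c1ccc(F)cc1F` differs from compound 1 at a different place: ((pyridin-4-yl)methyl)amino in place of ethoxy on a carbonyl carbon. Within the data shown here, none of the measured steps touches this carbonyl carbon, so they give no direct guide to the change. With no comparison available, the expected step is no change at the digits printed from compound 1 to compound 4 (within the scatter), small but very uncertain. Compound 4 is therefore estimated at 300 nM, within a wide range from 60 nM to 1500 nM.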

Compound 4, half-maximal inhibitory concentration: 500 nM
For compound 4 the middle estimate is 1.7-fold (0.22 log units) below the measured one; low and high end bracket the measured number.
By their numbers in this assay, from the lowest: compounds 2, 1 and 4 (each within the scatter of the next, the first and the last beyond it); then compound 3.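

In this assay the change of ethoxy to ((pyridin-4-yl)methyl)amino on the carbonyl carbon gives a 1.7-fold higher number from compound 1 to compound 4 (0.22 log units; within the scatter) and so stays small. Among these compounds, this place, untouched by the earlier steps, thus accepts an amide with a six-membered aromatic ring and 8 heavy atoms in place of an ester group with 3. No measurement shown accounts for this result.

As far as these compounds go, a carboxylic acid or a simple methyl amide on this carbonyl carbon remains open. So does whether the ((pyridin-4-yl)methyl)carbamoyl group would behave the same alongside the methyl or butyl groups on the sulfonyl sulfur of compound 2 and compound 3.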